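Thiophene in place of methyl on the sulfonamide

The compounds below may be only part of what the source reports. "The series", "measured", "known", "first", "only" and "open" are said of these compounds alone.

Compound 1 `COC(=O)N[C@H]1Cc2ccc(NC(=O)c3cc(C)ccc3-c3ccc(C(F)(F)F)cc3)cc2C1`: in an assay on isolated protein for inhibition of microsomal triglyceride transfer protein large subunit (Homo sapiens) (a lower number here means a stronger inhibitor, a higher number a weaker inhibitor), compound 1 gives 170 nM.
Compound 2 `Cc1cccc(C(=O)Nc2ccc3c(c2)CC(NS(=O)(=O)c2ccccc2)C3)c1-c1ccc(Cl)cc1`: in this assay compound 2 gives 100 nM.
Compound 3 `Cc1cccc(C(=O)Nc2ccc3c(c2)CC(NS(C)(=O)=O)C3)c1-c1ccc(Cl)cc1`: in this assay compound 3 gives 100 nM.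

Compound 3 stands level with compound 2; together they hold the lowest numbers of the three, and compound 1 sits only slightly higher, within the scatter. Compound 4 `Cc1cccc(C(=O)Nc2ccc3c(c2)CC(NS(=O)(=O)c2cccs2)C3)c1-c1ccc(Cl)cc1` differs from compound 3 by thiophen-2-yl in place of methyl on a sulfonyl sulfur. Among the measured compounds shown here, one measured step touches this position: no change at the digits printed from compound 2 to compound 3 (within the scatter), where a phenyl on the sulfonyl sulfur was exchanged for methyl without any shift. Thiophen-2-yl, like that phenyl, is an aromatic ring on the same sulfur, so the step of no change at the digits printed from compound 3 to compound 4 (within the scatter) is expected to stay within the scatter. Compound 4 is therefore estimated at 100 nM, with a range from 50 nM to 220 nM.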

Compound 4, half-maximal inhibitory concentration: 120 nM
Beside the measured number, compound 4's estimate is 1.2-fold (0.08 log units) below it; low and high end bracket the measured number.
By their numbers in this assay, from the lowest: compounds 2, 3, 4 and 1 (each within the scatter of the next).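

Thiophen-2-yl in place of methyl gives a 1.2-fold higher number from compound 3 to compound 4 (0.08 log units; within the scatter) in this assay, and thiophen-2-yl in place of phenyl gives a 1.2-fold higher number from compound 2 to compound 4 (0.08 log units; within the scatter) in the same test. A five-membered aromatic ring with a sulfur in it therefore joins methyl and phenyl on this sulfonyl sulfur, and the three compounds cannot be told apart here. Nothing measured here explains why this position accepts such different groups. Still open, on these data alone, is whether the same holds for a sulfonyl sulfur carrying a longer chain, or a group bearing an amine or a carboxylic acid.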